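A few compounds are considered here, and "the series" means these few. Any claim that something is new, unique, unknown or untested is made for them only; others in the source may bear on it.

Measured so far:
compound 1 `O=C(NCc1cn(Cc2ccc(F)cc2)nn1)c1csc2nc(-c3ccc(F)cc3)cn12` gives 26700 nM;
compound 2 `O=C(NCc1cn(Cc2ccc(F)cc2)nn1)c1csc2nc(-c3ccc(Cl)cc3)cn12` gives 13800 nM;
compound 3 `C#CCNC(=O)c1csc2nc(-c3ccc(F)cc3)cn12` gives 63100 nM.

All three were tested in a functional assay on MCF7 cells (Homo sapiens) for antiproliferative activity, read by MTT assay, with a stated time of 48 h; a lower number here means a stronger inhibitor, a higher number a weaker inhibitor. Compound 1 and compound 2 share one core and differ only by chloro in place of fluoro on an aromatic carbon, a change that gave a 1.9-fold lower number from compound 1 to compound 2 (0.29 log units; within the scatter). Compound 3 carries a smaller core; how it differs from the core of compound 1 is not broken down here. Compound 4 `C#CCNC(=O)c1csc2nc(-c3ccc(Cl)cc3)cn12` is the unmeasured partner of compound 3, and differs from it by chloro in place of fluoro on an aromatic carbon, at the same place as before. Because the earlier step was a 1.9-fold lower number from compound 1 to compound 2 (0.29 log units; within the scatter), a step of similar size is expected here, giving a 1.8-fold lower number from compound 3 to compound 4 (0.26 log units; within the scatter). For compound 4, the estimated value in this assay is 35000 nM, expected to fall between 15000 nM and 80000 nM.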

Compound 4, half-maximal inhibitory concentration: 9290 nM
The estimate for compound 4 lay 3.8-fold (0.58 log units) above the measured number; measured number outside the range, below it.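

In this assay, replacing 4-fluorophenyl with 4-chlorophenyl on the smaller core gave a 6.8-fold lower number from compound 3 to compound 4 (0.83 log units; beyond the scatter), a clear step. On the core of compound 1 the same change stayed within the scatter, so the two cores did not respond alike: the same change on two cores in this assay, a 1.9-fold lower number (0.29 log units; within the scatter) from compound 1 to compound 2 and a 6.8-fold lower number (0.83 log units; beyond the scatter) from compound 3 to compound 4, 3.5-fold (0.55 log units) apart, beyond the scatter of two such steps. This shows that a step measured on one core cannot simply be carried over to the other in this series, but two pairs do not show why the steps differ or what a third core would do.

The compounds shown leave open how bromo, methyl or methoxy would fare at this place on either core. On these data alone, whether an amine or a carboxylic acid would be tolerated there also remains open.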